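The source may hold more compounds than are shown below. What is called first, only, known or untested is meant among the compounds shown, and "the series" means these compounds.

Of the compounds shown here, two have been measured so far in an ADME assay on L6 cells (Rattus norvegicus) for cytotoxicity, read by resazurin assay, with a stated time of 72 h (on this read-out lower numbers stand for stronger inhibition and higher numbers for weaker inhibition), and their values are these.
- Compound 1 `N=C(N)c1ccc(COc2ccccc2)cc1` gives 167000000 nM
- Compound 2 `N=C(N)c1ccc(COc2ccc([N+](=O)[O-])cc2)cc1` gives 79200000 nM

For the measured compounds named here, compound 2 holds the lower of the two numbers at 79200000 nM and lies just beyond the scatter from compound 1, its only neighbour. The next compound to be read is compound 3 `N=C(N)c1ccc(COc2ccc(Cl)cc2)cc1` and it differs from compound 2 as follows chloro in place of nitro on an aromatic carbon with the change para to a large group.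

Going by the values given here, only one measured step bears on this change, and it does so indirectly. It is a 2.1-fold lower number from compound 1 to compound 2 (0.32 log units; beyond the scatter) for nitro in place of hydrogen, which is modest. Among the compounds with values here, no measurement yet compares chloro with nitro, so that step serves only as a gauge of size. In this assay a smaller step is therefore expected, within the scatter, with a slight lean toward higher numbers. The expected change is a 1.3-fold higher number from compound 2 to compound 3 (0.10 log units; within the scatter) and no more than that. For compound 3 the estimate is 100000000 nM with an expected range from 40000000 nM to 220000000 nM for the measurement.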

Compound 3, half-maximal inhibitory concentration: 20700000 nM
The estimate for compound 3 lay 4.8-fold (0.68 log units) above the measured number, and the stated range ends above it.
By their numbers in this assay, from the lowest: compound 3; then compound 2; then compound 1.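

In this assay, the position on the aromatic ring para to a large group now has three occupants, and the choice among them moves the number further than the step from hydrogen to nitro did: chloro in place of nitro gives a 3.8-fold lower number from compound 2 to compound 3 (0.58 log units; beyond the scatter), and chloro in place of hydrogen gives an 8.1-fold lower number from compound 1 to compound 3 (0.91 log units; beyond the scatter). Both groups at this place give lower numbers than hydrogen, but they are not interchangeable, since chloro stands beyond the scatter from nitro, so the outcome depends on which group enters and not merely on the hydrogen leaving. Nothing available speaks to what lies behind this difference between chloro and nitro.

The compounds shown leave open whether other groups at this place, such as fluoro, bromo, methoxy or an amine, would fall nearer to chloro, nearer to nitro or outside the range of the three. They also leave open whether chloro at another place on the same ring would give a step of similar size.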